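Methyl in Place of a Ring Nitrogen Hydrogen: An Estimate

This account rests on a few compounds, and the source may have more. Where it says the series, first, only, none or still open, it means among the compounds named here.

Compound 1 `N#Cc1c(-c2ccccc2)nc(SCC(=O)Nn2c(COc3ccc(Cl)cc3Cl)nc3ccccc3c2=O)[nH]c1=O`: 81.8%
Compound 2 `N#Cc1c(-c2ccc(Cl)cc2)nc(SCC(=O)Nn2c(COc3ccc(Cl)cc3Cl)nc3ccccc3c2=O)[nH]c1=O`: 63.6%

In a functional assay on the whole organism (strain albino) for inhibition, with Rattus norvegicus as the target, read by paw edema, with a stated time of 1 h, at a dose of 100 mg/kg by the oral route (on this read-out lower numbers stand for less inhibition and higher numbers for more inhibition at the one dose given (going by the name of the read-out)), compound 1 gives 81.8%, the higher of the two numbers measured, while compound 2 gives 63.6%. Going by the values given here, the one measured step, a number 18.2 percentage points lower from compound 1 to compound 2 (beyond the scatter), came from a chloro in place of hydrogen on an aromatic carbon. Compound 3 `Cn1c(SCC(=O)Nn2c(COc3ccc(Cl)cc3Cl)nc3ccccc3c2=O)nc(-c2ccccc2)c(C#N)c1=O` differs from compound 1 by methyl in place of hydrogen on an aromatic nitrogen, on an aromatic nitrogen of a six-membered aromatic ring with 2 nitrogen. Among the compounds with values here, no measured step touches that position, so the change is expected to give a number 9.8 percentage points lower from compound 1 to compound 3 (within the scatter), probably within the scatter. Compound 3 is therefore estimated at 72%, between 52% and 88%.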

Compound 3, a percentage reported as inhibition, in the whole organism at one dose (the size of the read-out at that dose, not a potency): 54.6%
Compound 3: the middle estimate sits 17.4 percentage points above what was measured, within the range that was stated.
By their numbers in this assay, from the lowest: compounds 3 and 2 (each within the scatter of the next); then compound 1.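

In this assay, the ring nitrogen proves sensitive to substitution: methyl in place of hydrogen on this aromatic nitrogen gives a number 27.2 percentage points lower from compound 1 to compound 3 (beyond the scatter). So adding a single carbon here is enough to move the read-out past the usual scatter, which the chloro step elsewhere on the molecule could not have revealed. No measurement shown explains this fall.

From the compounds shown here alone, whether an ethyl group or a longer chain on this nitrogen would lower the number further remains open. So does the size of the same methyl step on compound 2.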